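The source may report more compounds than this note shows. Statements on the series, on what has been measured and on what is new or still open speak of the compounds shown alone.

Measured so far in a functional assay on RAW264.7 cells (Mus musculus) for inhibition, read by ELISA, with stated times of 30 min and 24 h; on this read-out higher numbers stand for weaker inhibition and lower numbers for stronger inhibition:
compound 1 `CN1CCN(c2ccc(NC(=O)c3cc4cc(NC(=O)c5ccco5)ccc4n3Cc3ccc(C(F)(F)F)cc3)cc2)CC1` gives 2900 nM
compound 2 `C=CC(=O)Nc1ccc2c(c1)cc(C(=O)Nc1ccc(N3CCN(C)CC3)cc1)n2Cc1ccc(C(F)(F)F)cc1` gives 6280 nM

Compound 2 holds the highest number of the two in this assay; its nearest neighbour is compound 1, and the step of a 2.2-fold higher number from compound 1 to compound 2 (0.34 log units; beyond the scatter) was a modest one, beyond the scatter, for vinyl in place of furan-2-yl on a carbonyl carbon.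

Compound 3 `CN1CCN(c2ccc(NC(=O)c3cc4cc([N+](=O)[O-])ccc4n3Cc3ccc(C(F)(F)F)cc3)cc2)CC1` is not yet measured. It differs from compound 2 by nitro in place of (vinylcarbonyl)amino on an aromatic carbon. Within the data shown here, the one measured step, from compound 1 to compound 2, changed only the group on the carbonyl carbon while the amide itself stayed in place; the present change removes that whole (vinylcarbonyl)amino group and puts nitro on the aromatic carbon instead. Among the measured compounds shown here, no measured step therefore bears on this change, and the direction in this assay cannot be read from the series. As a working figure the number for compound 3 is expected to sit near or somewhat above that of compound 2, with a wide range, the expected step being a 1.4-fold higher number from compound 2 to compound 3 (0.16 log units; within the scatter). The estimate for compound 3 in this assay is 9000 nM, between 3000 nM and 30000 nM.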

Compound 3, half-maximal inhibitory concentration: 5090 nM
Estimate against measurement, compound 3: 1.8-fold (0.25 log units) above, and the stated range covers the measured number.
By their numbers in this assay, from the lowest: compounds 1, 3 and 2 (each within the scatter of the next, the first and the last beyond it).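

In this assay, replacing the whole amide at this aromatic carbon leaves the number within the scatter: nitro in place of (vinylcarbonyl)amino gives a 1.2-fold lower number from compound 2 to compound 3 (0.09 log units; within the scatter), and nitro in place of ((furan-2-yl)carbonyl)amino gives a 1.8-fold higher number from compound 1 to compound 3 (0.24 log units; within the scatter). The earlier pair varied only the group on the carbonyl carbon, whereas this change also gives up the amide hydrogen, so these numbers show that a hydrogen-bond donor on this carbon is not needed to stay in the range of the two amides, even though the step between those amides is a 2.2-fold higher number from compound 1 to compound 2 (0.34 log units; beyond the scatter). Nothing measured here explains why the nitro compound falls within the scatter of both amides.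

Still open, as far as these compounds go, is whether any group on this aromatic carbon moves the number well beyond the scatter of these three, for example a simple amine, a carboxylic acid or a longer chain. All the compounds shown share the rest of the core, so whether the same insensitivity at this carbon holds with other groups elsewhere on it also remains unknown.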